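Three Limits and a Bromophenyl Swap

The source may report more compounds than this note shows. Statements on the series, on what has been measured and on what is new or still open speak of the compounds shown alone.

Measured compounds:
Compound 1, `COc1ccc(-c2cc(=O)c3c(OC)cc(OC)cc3n2S(=O)(=O)c2ccc(C=O)cc2)cc1`. In a functional assay on SUP-B15 cells (Homo sapiens) for antiproliferative activity, with a stated time of 72 h (on this read-out lower numbers stand for an effect already at smaller amounts and higher numbers for an effect only at larger amounts of compound), compound 1 gives > 34400 nM, which is a limit of the assay and not a number.
Compound 2, `COc1ccc(-c2cc(=O)c3c(OC)cc(OC)cc3n2S(=O)(=O)c2ccc(C)c([N+](=O)[O-])c2)cc1`. In this assay compound 2 gives > 51700 nM, again a limit of the assay.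
Compound 3, `COc1ccc(-c2cc(=O)c3c(OC)cc(OC)cc3n2S(=O)(=O)c2ccc(F)cc2)cc1`. In this assay compound 3 gives > 65500 nM, also a limit of the assay.

Compound 3 cannot be placed in any order among the measured compounds: every value shown is a limit, as the limit of > 34400 nM in this assay, at which 1 of the 3 values shown sits, the limit of > 51700 nM in this assay, at which 1 of the 3 values shown sits, and the limit of > 65500 nM in this assay, at which 1 of the 3 values shown sits, make clear. For the same reason the steps a step that the two limits leave unreadable from compound 1 to compound 3 and a step that the two limits leave unreadable from compound 2 to compound 3 have no readable size, and neither has a step that the two limits leave unreadable from compound 1 to compound 2.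

Compound 4, `COc1ccc(-c2cc(=O)c3c(OC)cc(OC)cc3n2S(=O)(=O)c2cccc(Br)c2)cc1`, differs from compound 3 in one place: 3-bromophenyl in place of 4-fluorophenyl on a sulfonyl sulfur. All three measured changes of the aryl group on the sulfonyl sulfur run from one limit to another, so none of them gives a size that would bear on this swap. The expectation for compound 4 is therefore no change beyond the scatter, and most likely a further limit rather than a number. The step expected here is an at least 1.0-fold lower number from compound 3 to compound 4 (0.03 log units; that floor lies within the scatter). Compound 4 is estimated at 60000 nM, with a range from 20000 nM to 200000 nM.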

Compound 4, half-maximal effective concentration: > 58600 nM
Compound 4: a limit, no number; the forecaster's own chance of this, stated with the estimate: 85%; the middle value does not contradict the limit.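

Compound 4 also gives only a limit of the assay, and the steps to it from compound 1, compound 2 and compound 3 cannot be read. The compounds shown leave open whether swapping the aryl group on the sulfonyl sulfur changes the read-out in this assay at all, and by how much.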